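Second methoxy on the benzoyl ring of compound 1

A few compounds are considered here, and "the series" means these few. Any claim that something is new, unique, unknown or untested is made for them only; others in the source may bear on it.

Measured compounds:
- compound 1, `COc1ccc(C(=O)NNC(=S)Nc2csc(-c3ccc(C)cc3)c2)cc1`: 9000 nM
- compound 2, `Cc1ccc(-c2cc(NC(=S)NNC(=O)c3ccc(O)cc3)cs2)cc1`: 48000 nM

In a functional assay on B16-F10 cells (Mus musculus) for inhibition, read by colorimetric assay and MTT assay, with a stated time of 72 h (a higher number here means a weaker inhibitor, a lower number a stronger inhibitor), compound 1 gives 9000 nM, the lowest of the two numbers at hand. Compound 2 sits furthest from it: a 5.3-fold higher number from compound 1 to compound 2 (0.73 log units; beyond the scatter).

Compound 3, `COc1ccc(C(=O)NNC(=S)Nc2csc(-c3ccc(C)cc3)c2)cc1OC`, differs from compound 1 in one place: methoxy in place of hydrogen on an aromatic carbon. The new methoxy sits ortho to the methoxy already present and meta to a large group.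

Among the measured compounds shown here, only one measured step exists, and it touches the same ring: removing the methyl from the oxygen, a 5.3-fold higher number from compound 1 to compound 2 (0.73 log units; beyond the scatter), a modest change beyond the scatter. For the measured compounds named here, that step shows the ring tolerates alteration at this oxygen without a collapse, but it does not concern adding a second methoxy, and no other pair shows that change. The expectation for compound 3 is therefore a step from compound 1 of no size beyond the scatter, in either direction, with the uncertainty widened by the missing precedent: no change at the digits printed from compound 1 to compound 3 (within the scatter) is expected.

For compound 3 the estimate in this assay is 9000 nM, ranging from 3000 nM to 27000 nM.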

Compound 3, half-maximal inhibitory concentration: 7000 nM
Compound 3: the middle estimate sits 1.3-fold (0.11 log units) above what was measured, and the stated range covers the measured number.
By their numbers in this assay, from the lowest: compounds 3 and 1 (each within the scatter of the next); then compound 2.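

In this assay, methoxy in place of hydrogen on an aromatic carbon, ortho to a methoxy group and meta to a large group, gives a 1.3-fold lower number from compound 1 to compound 3 (0.11 log units; within the scatter), so this position takes the added methoxy with no change that can be told apart from the scatter of repeated measurements. Among the compounds shown here, the earlier step, a 5.3-fold higher number from compound 1 to compound 2 (0.73 log units; beyond the scatter), concerned only the oxygen already present on this ring and said nothing about a new group at a free carbon, so this is the first view of that position. The data at hand offer no measurement that would explain this result.

As far as these compounds go, a single added group says little about the position as a whole, so it remains open whether an amine, a carboxylic acid or a longer chain such as butoxy would be taken up as quietly as methoxy. From the compounds shown here alone, it is also open whether the same addition would give a similar result on compound 2, where that oxygen carries hydrogen in place of methyl.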